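This account rests on a few compounds, and the source may have more. Where it says the series, first, only, none or still open, it means among the compounds named here.

The measured compounds and their results in a functional assay on U-87MG ATCC cells for antiproliferative activity against U-87 MG (Homo sapiens), read by MTT assay, with a stated time of 48 h, tested at 50 uM; on this read-out higher numbers stand for a weaker effect at the one concentration tested and lower numbers for a stronger effect:

Compound 1 `Cc1nc(-c2ccc(Cl)cc2)sc1C(=O)CSc1nc(-c2ccc(Cl)c(Cl)c2)c(C#N)c(=O)[nH]1` gives 93.9%.
Compound 2 `Cc1nc(-c2ccc(Cl)cc2)sc1C(=O)CSc1nc(-c2cccc(Cl)c2)c(C#N)c(=O)[nH]1` gives 52.6%.
Compound 3 `Cc1nc(-c2ccccc2)sc1C(=O)CSc1nc(N)c(C#N)c(-c2ccc(Cl)cc2)n1` gives 44.3%.

Compound 1 and compound 2 differ in one place, (hydrogen in place of chloro on an aromatic carbon), and this change made a large step: a number 41.3 percentage points lower from compound 1 to compound 2 (beyond the scatter). Compound 3 is built on a different core; the difference between the two cores is not broken down here. Compound 3 stands nearest compound 2, the two numbers being within the usual scatter, and far from compound 1.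

Compound 4 `Cc1nc(-c2ccccc2)sc1C(=O)CSc1nc(N)c(C#N)c(-c2ccccc2)n1` is not yet measured. It differs from compound 3 by hydrogen in place of chloro on an aromatic carbon. Going by the values given here, this is the same kind of change as the one from compound 1 to compound 2, but not the same: in compound 1 the place is ortho to a chloro group, and no such group stands around the place in compound 3. Among the compounds with values here, since the only measured step of this kind, a number 41.3 percentage points lower from compound 1 to compound 2 (beyond the scatter), was a large lowering, a lowering is expected again, though a smaller one on the other core. The step is estimated as a number 9.3 percentage points lower from compound 3 to compound 4 (within the scatter). Compound 4 is therefore expected to give 35%, likely between 15% and 60%.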

Compound 4, a percentage reported as activity, at one concentration (the size of the read-out at that concentration, not a potency): 26.3%
For compound 4 the middle estimate is 8.7 percentage points above the measured one; low and high end bracket the measured number.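

In this assay, putting hydrogen in place of chloro on the aromatic carbon again gave a lower number, a number 18 percentage points lower from compound 3 to compound 4 (beyond the scatter), so the direction of the change held on the second core while its size did not: the same change on two cores in this assay, a number 41.3 percentage points lower (beyond the scatter) from compound 1 to compound 2 and a number 18 percentage points lower (beyond the scatter) from compound 3 to compound 4, 23.3 percentage points apart, beyond the scatter of two such steps

This rests on one pair per core, and the two pairs also differ in their surroundings: the ring in compound 2 keeps a second chloro, whereas the change from 4-chlorophenyl to phenyl leaves compound 4 with no chloro at all. The data therefore show that the step cannot be assumed to keep its size from one core to another, but they do not show whether the core or those surroundings set the size, nor do they give a cause.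

The compounds shown leave open how a fluoro, a methoxy or an amine would read at the place where chloro and hydrogen were exchanged. All four carry the nitrile, so a carboxylic acid in its place also remains an open question.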